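This account rests on a few compounds, and the source may have more. Where it says the series, first, only, none or still open, it means among the compounds named here.

In an in vitro ADME assay on microsomes from liver (Homo sapiens) for pharmacokinetics, read by LC-MS, with a stated time of 10 min, tested at 1 uM (a higher number here means faster removal of the compound, a lower number slower removal), compound 1 `CN1C[C@H](C(=O)Nc2ccccc2F)[C@@H](c2ccc(/C=C/C(=O)Nc3ccccc3N)cc2)C1` gives 10 mL/min/kg and compound 2 `CN1C[C@H](C(=O)Nc2ccc(F)c(Cl)c2)[C@@H](c2ccc(/C=C/C(=O)Nc3ccccc3N)cc2)C1` gives 15 mL/min/kg, two values within the scatter of each other. Compound 3 `Cc1cc(NC(=O)[C@H]2CN(C)C[C@@H]2c2ccc(/C=C/C(=O)Nc3ccccc3N)cc2)ccc1Cl` has 4-chloro-3-methylphenyl in place of 3-chloro-4-fluorophenyl on an amide-type nitrogen. For the measured compounds named here, the only measured step at that amide-type nitrogen is a 1.5-fold higher number from compound 1 to compound 2 (0.18 log units; within the scatter), which stays within the scatter. No step beyond the scatter is therefore expected in this assay, and no direction can be assigned. The expected step is a 1.1-fold higher number from compound 2 to compound 3 (0.03 log units; within the scatter). The estimate for compound 3 is 16 mL/min/kg, with an expected range of 8 mL/min/kg to 32 mL/min/kg.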

Compound 3, clearance: 15 mL/min/kg
For compound 3 the middle estimate is 1.1-fold (0.03 log units) above the measured one, and the stated range covers the measured number.
By their numbers in this assay, from the lowest: compounds 1, 2 and 3 (each within the scatter of the next).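

In this assay, 4-chloro-3-methylphenyl in place of 3-chloro-4-fluorophenyl shows no change at the digits printed from compound 2 to compound 3 (within the scatter) and, in place of 2-fluorophenyl, shows a 1.5-fold higher number from compound 1 to compound 3 (0.18 log units; within the scatter) on the amide-type nitrogen. A third substituted phenyl group, now one carrying a methyl group, therefore still gives no step beyond the scatter at this position. No supporting data offer an explanation for this reading.

Going by these compounds, whether a group other than substituted phenyl, such as an amine, a carboxylic acid or a longer chain, would give a step beyond the scatter remains open.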